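This account rests on a few compounds, and the source may have more. Where it says the series, first, only, none or still open, it means among the compounds named here.

Compound 1 (`COc1ccc(-c2c(C)nc3c(N4CC[C@@H](NC(C)=O)C4)cc(C)nn23)cc1OC`) was tested in an ADME assay on microsomes from liver (Homo sapiens) for metabolic stability, read by LC-MS, with NADPH named in the record, with a stated time of 60 min, tested at 1 uM, in the absence of a further agent (on this read-out higher numbers stand for a more stable compound and lower numbers for a less stable compound), where compound 1 gives > 95%, which is a limit of the assay and not a number. Compound 2 (`COc1ccc(-n2c(C)nc3c(N4CC[C@@H](NC(C)=O)C4)nc(C)nc32)cc1OC`), which carries a different core, gives > 95% in this assay, and this too is a limit. Across the pair, the picture is therefore (the limit of > 95% in this assay, at which 2 of the 2 values shown sit), so neither compound has an exact position on the scale. For the measured compounds named here, no step between measured compounds is available to serve as a guide.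

Compound 3 (`CC(=O)N[C@@H]1CCN(c2cc(C)nn3c(-c4ccccc4)c(C)nc23)C1`) keeps the core of compound 1 and has phenyl in place of 3,4-dimethoxyphenyl on an aromatic carbon of a five-membered aromatic ring (phenyl in place of 3,4-dimethoxyphenyl on an aromatic carbon). The expectation for this change rests on compound 1 alone, with its limit of > 95% as the only anchor. No shift beyond the usual scatter is expected in this assay, and any movement is expected to be slightly downward. The estimated step is a number at least 2 percentage points lower from compound 1 to compound 3 (that floor lies within the scatter). The value expected for compound 3 is 93%, with an estimated range of 80% to 100%.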

Compound 3, percent of the compound remaining: > 95%
Compound 3: no number, only a limit (the forecaster's own chance of this, stated with the estimate: 50%); middle value at least 2 percentage points from the limit.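

In this assay compound 3 gives > 95%, which is a limit of the assay and not a number. With compound 1 also at a limit, no step between compound 1 and compound 3 can be read: the limit of > 95% in this assay, at which 3 of the 3 values shown sit.

The compounds shown leave open whether phenyl and 3,4-dimethoxyphenyl at this place differ at all in this assay.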